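A Nitrooxy Chain Enters the Acetate Ester

The source may hold more compounds than are shown below. What is called first, only, known or untested is meant among the compounds shown, and "the series" means these compounds.

Three compounds share one core and are compared in an ADME assay on a cell-free system (plasma, Homo sapiens) for metabolic stability, with Plasma (Rattus norvegicus) as the target, read by HPLC, at pH 7.4; on this read-out lower numbers stand for a shorter-lived compound and higher numbers for a longer-lived compound. Compound 1 `CC(=O)Oc1ccccc1C(=O)O[C@H]1CO[C@H]2[C@@H]1OC[C@H]2OC(=O)c1ccccc1O` gives 0.0825 h. Compound 2 `CC(=O)Oc1ccccc1C(=O)O[C@H]1CO[C@H]2[C@@H]1OC[C@H]2OC(=O)c1cccc(O)c1` gives 0.0183 h. Compound 3 `CC(=O)Oc1ccccc1C(=O)O[C@H]1CO[C@H]2[C@@H]1OC[C@H]2OC(C)=O` gives 0.0608 h, the second highest of the three numbers; its nearest neighbour is compound 1, where the step of a 1.4-fold lower number from compound 1 to compound 3 (0.13 log units; within the scatter) stays within the scatter, and its furthest is compound 2, where the step of a 3.3-fold higher number from compound 2 to compound 3 (0.52 log units; beyond the scatter) goes beyond it. The remaining step, a 4.5-fold lower number from compound 1 to compound 2 (0.65 log units; beyond the scatter), shows that exchanging one hydroxyphenyl for the other moves the number more than exchanging either for methyl.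

Compound 4 `CC(=O)Oc1ccccc1C(=O)O[C@H]1CO[C@H]2[C@@H]1OC[C@H]2OC(=O)CCO[N+](=O)[O-]` differs from compound 3 in one place: (nitrooxy)methyl in place of hydrogen on a saturated chain carbon bound to a carbonyl carbon. Among the measured compounds shown here, none of the measured steps touches this place; all three concern the group on the carbonyl carbon, and the one that reaches methyl, compound 1 to compound 3, sits within the scatter. The data therefore give no direction for this change. The expected step of a 1.2-fold lower number from compound 3 to compound 4 (0.08 log units; within the scatter) is small, with more room left on the lower side. Compound 4 is estimated at 0.05 h, within the range 0.015 h to 0.15 h.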

Compound 4, half-life: 0.065 h
For compound 4 the middle estimate is 1.3-fold (0.11 log units) below the measured one; measured number inside the range.
By their numbers in this assay, from the lowest: compound 2; then compounds 3, 4 and 1 (each within the scatter of the next).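

Placing (nitrooxy)methyl on a saturated chain carbon bound to a carbonyl carbon is the first change shown at this position, and in this assay it gives a 1.1-fold higher number from compound 3 to compound 4 (0.03 log units; within the scatter), so the half-life does not separate the two compounds. The larger 2-(nitrooxy)ethyl group on the carbonyl carbon sits much as methyl does relative to the two hydroxyphenyl compounds: a 1.3-fold lower number from compound 1 to compound 4 (0.10 log units; within the scatter) stays within the scatter, while a 3.6-fold higher number from compound 2 to compound 4 (0.55 log units; beyond the scatter) goes beyond it, leaving compound 2 apart from the other three. No measurement shown accounts for this lack of change at the new position.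

Among the compounds shown here, with only one group at this position, it remains open whether a longer chain, an amine or a carboxylic acid in place of the (nitrooxy)methyl would also leave the half-life unchanged. The compounds shown also cannot separate the nitrooxy group from the chain carrying it, as that would take a comparison with a plain ethyl or a 2-hydroxyethyl group on the same carbonyl carbon.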